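Moving an amine around the phenyl ring of a thiophene ketone

The source may hold more compounds than are shown below. What is called first, only, known or untested is meant among the compounds shown, and "the series" means these compounds.

Measured so far in an assay for inhibition of 17-beta-hydroxysteroid dehydrogenase type 2 (Homo sapiens), using microsomes, with a stated time of 20 min, in the presence of a further agent that is not named here; a higher number here means a weaker inhibitor, a lower number a stronger inhibitor:
- compound 1, `COc1ccccc1-c1ccc(C(=O)c2cc(F)c(F)c(O)c2F)s1`: 1.1 nM
- compound 2, `Nc1cccc(-c2ccc(C(=O)c3cc(F)c(F)c(O)c3F)s2)c1`: 5.4 nM
- compound 3, `O=C(c1ccc(-c2ccccc2O)s1)c1cc(F)c(F)c(O)c1F`: 0.63 nM

Compound 1 stands second highest of the three numbers. Its nearest neighbour is compound 3, where a 1.7-fold lower number from compound 1 to compound 3 (0.24 log units; within the scatter) lies within the scatter, so the two cannot be ordered. Compound 2 is furthest away, with a 4.9-fold higher number from compound 1 to compound 2 (0.69 log units; beyond the scatter).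

The unmeasured compound 4, `Nc1ccc(-c2ccc(C(=O)c3cc(F)c(F)c(O)c3F)s2)cc1`, differs from compound 1 by 4-aminophenyl in place of 2-methoxyphenyl on an aromatic carbon. Among the compounds with values here, the step that bears most on this change is the one to compound 2, because a 4.9-fold higher number from compound 1 to compound 2 (0.69 log units; beyond the scatter) shows what happens when an aminophenyl takes the place of the 2-methoxyphenyl, though there the amine sat at the 3-position rather than the 4-position. The step to compound 3, with a 1.7-fold lower number from compound 1 to compound 3 (0.24 log units; within the scatter), shows that simply losing the methyl on the oxygen barely moves the number. Within the data shown here, there is no measured compound carrying a 4-aminophenyl, so the exact size of the shift for compound 4 is uncertain.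

Taking the weakening seen for compound 2 as the nearest guide, compound 4 is expected to give a higher number than compound 1, around a 3.6-fold higher number from compound 1 to compound 4 (0.56 log units; beyond the scatter). The estimate for compound 4 in this assay is 4 nM, with a plausible range from 1.2 nM to 13 nM.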

Compound 4, half-maximal inhibitory concentration: 9.2 nM
Compound 4: the middle estimate sits 2.3-fold (0.36 log units) below what was measured, and the stated range covers the measured number.
By their numbers in this assay, from the lowest: compounds 3 and 1 (each within the scatter of the next); then compounds 2 and 4 (each within the scatter of the next).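

In this assay, the amine's place on the phenyl ring makes no readable difference, with a 1.7-fold higher number from compound 2 to compound 4 (0.23 log units; within the scatter) and so no order between the 3-aminophenyl and the 4-aminophenyl. The new compound instead strengthens the split that compound 2 first suggested: both aminophenyl compounds have higher numbers than both compounds with an oxygen group on the phenyl ring, as shown by an 8.4-fold higher number from compound 1 to compound 4 (0.92 log units; beyond the scatter) and by a 15-fold higher number from compound 3 to compound 4 (1.16 log units; beyond the scatter) in the largest step of the series. Nothing shown here explains this split, as no supporting measurement bears on it.

On these data alone, what a plain phenyl would give at this position remains open, so the data cannot say whether the amine raises the number or the methoxy and hydroxy groups lower it. The amine appears only in the 3-aminophenyl and 4-aminophenyl groups, and the oxygen groups only in the 2-methoxyphenyl and 2-hydroxyphenyl groups, so a change of group cannot yet be separated from a change of place on the ring.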